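The compounds below may be only part of what the source reports. "The series", "measured", "known", "first", "only" and "open" are said of these compounds alone.

Measured in an ADME assay on HEK-293T cells (Homo sapiens) for cytotoxicity, read by MTT assay, with a stated time of 24 h; a higher number here means that more compound is tolerated, a lower number that less compound is tolerated:
Compound 1 `Cc1ccc(-c2nn(-c3ccccc3)cc2-c2nc3ccccc3n2S(=O)(=O)c2ccccc2)cc1`: 138000 nM
Compound 2 `O=S(=O)(c1ccccc1)n1c(-c2cn(-c3ccccc3)nc2-c2ccc(C(F)(F)F)cc2)nc2ccccc21`: 128000 nM

Compound 2, at 128000 nM, stands level with compound 1 within the scatter. Compound 3 `O=S(=O)(c1ccc(F)cc1)n1c(-c2cn(-c3ccccc3)nc2-c2ccc(C(F)(F)F)cc2)nc2ccccc21` carries one change from compound 2: fluoro in place of hydrogen on an aromatic carbon, turning phenylsulfonyl to (4-fluorophenyl)sulfonyl. Among the measured compounds shown here, the only measured step, a 1.1-fold lower number from compound 1 to compound 2 (0.03 log units; within the scatter), was trifluoromethyl in place of methyl at another place, so it bears only indirectly. For the measured compounds named here, no measured step covers this fluoro change. Hence no step beyond the scatter is expected in this assay. The expected step is a 1.1-fold lower number from compound 2 to compound 3 (0.03 log units; within the scatter). Compound 3 is estimated at 120000 nM, with an expected range of 60000 nM to 230000 nM.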

Compound 3, half-maximal cytotoxic concentration: 157000 nM
The estimate for compound 3 lay 1.3-fold (0.12 log units) below the measured number; the range from low to high includes it.
By their numbers in this assay, from the lowest: compounds 2, 1 and 3 (each within the scatter of the next).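

In this assay, among the compounds shown here, fluoro in place of hydrogen, turning phenylsulfonyl into (4-fluorophenyl)sulfonyl, gives a 1.2-fold higher number from compound 2 to compound 3 (0.09 log units; within the scatter) and so adds no step beyond the scatter on this ring, where the earlier compounds showed no change at all. The sulfonyl-bound ring therefore accepts this single fluorine without a clear shift in the tolerated concentration. No measurement at hand offers an explanation for this result.

Going by these compounds, whether an amine or a carboxylic acid at this same place would also stay level with compound 2 remains open. So does whether a chlorine or a methoxy group would behave as fluoro does here.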